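This account rests on a few compounds, and the source may have more. Where it says the series, first, only, none or still open, it means among the compounds named here.

Measured so far in a functional assay on BMDM cells (Mus musculus, strain C57BL/6) for inhibition, with a stated time of 2 days; on this read-out higher numbers stand for weaker inhibition and lower numbers for stronger inhibition:
Compound 1 `O=C(Cn1cc(-c2ccc([N+](=O)[O-])cc2)nn1)Nc1nccs1` gives 1040 nM.
Compound 2 `CCOC(=O)c1sc(NC(=O)Cn2cc(-c3ccc(OC)cc3)nn2)nc1C` gives 2330 nM.
Compound 3 `O=C(Cn1cc(-c2ccc([N+](=O)[O-])cc2)nn1)Nc1nc2ccccc2s1` gives 3280 nM.

Compound 1 has the lowest number of the three, and both steps from it are beyond the usual scatter: compound 2 lies a little higher, and the change a 3.2-fold higher number from compound 1 to compound 3 (0.50 log units; beyond the scatter) is a modest loss. Compound 4 `N#Cc1ccc(-c2cn(CC(=O)Nc3nccs3)nn2)cc1` differs from compound 1 in one place: cyano in place of nitro on an aromatic carbon. No measured step changes this group, so nothing shown bears directly on it; the one measured step concerns the amide-type nitrogen and carries no information on this position. Without a guide, the expectation for compound 4 is a step no larger than the scatter, in either direction, so compound 4 is estimated at 1400 nM (range 450 nM to 4500 nM), an expected step of a 1.3-fold higher number from compound 1 to compound 4 (0.13 log units; within the scatter).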

Compound 4, half-maximal inhibitory concentration: 270 nM
Estimate against measurement, compound 4: 5.2-fold (0.71 log units) above; the measured number lies below the stated range.
By their numbers in this assay, from the lowest: compound 4; then compound 1; then compounds 2 and 3 (each within the scatter of the next).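

The position on the aromatic carbon para to a large group is now shown to matter in this assay. Going by these compounds alone, replacing nitro with cyano there gives a 3.9-fold lower number from compound 1 to compound 4 (0.59 log units; beyond the scatter), so this group can move the read-out towards stronger inhibition, and compound 4 has the lowest number so far. No measurement shown explains this step.

From the compounds shown here alone, whether an amine, a carboxylic acid or a trifluoromethyl group at this position would lower the number further remains open. Also open, going by these compounds, is whether cyano would give a similar step alongside the 1,3-benzothiazol-2-yl group of compound 3.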